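Working notes: three measured analogues and one open position

The source may hold more compounds than are shown below. What is called first, only, known or untested is meant among the compounds shown, and "the series" means these compounds.

Compound 1 `Nc1cc(N)c2nc(-c3ccccc3)c(Oc3ccc(Cl)c(Cl)c3)nc2c1` in a functional assay on NCI-H23 cells (Homo sapiens) for inhibition, read by sulforhodamine B assay, with a stated time of 48 h (on this read-out lower numbers stand for stronger inhibition of growth and higher numbers for weaker inhibition of growth), gives 15500 nM.
Compound 2 `COc1cc(CNc2nc3cc(N)cc(N)c3nc2-c2ccccc2)cc(OC)c1OC` in this assay gives 8710 nM.
Compound 3 `CCOC(=O)[C@H](CCC(=O)O)NC(=O)c1ccc(Oc2nc3cc(N)cc(N)c3nc2-c2ccccc2)cc1` in this assay gives 15500 nM.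

Compound 1 stands level with compound 3 at the digits shown, the two together the highest numbers of the three; compound 2 sits at a lower number, but that gap is within the scatter, so no order among the three can be read. All three mark weak growth inhibition in a narrow band. Compound 4 `COc1ccc(Sc2nc3cc(N)cc(N)c3nc2-c2ccccc2)cc1` differs from compound 1 by (4-methoxyphenyl)sulfanyl in place of 3,4-dichlorophenoxy on an aromatic carbon. Within the data shown here, no measured pair shows the effect of such an exchange at this position, and the three numbers so far give no handle on direction. The step is expected to be small, in either direction, within the scatter: a 1.4-fold lower number from compound 1 to compound 4 (0.15 log units; within the scatter). Compound 4 is thus estimated at 11000 nM, with a range of 3500 nM to 35000 nM.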

Compound 4, concentration for 50% growth inhibition: < 100000 nM
Compound 4 ended at the assay's limit (the forecaster's own chance of this, stated with the estimate: 10%); the middle value does not contradict the limit.
By their numbers in this assay, from the lowest: compounds 2, 1 and 3 (each within the scatter of the next).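

Compound 4 gives < 100000 nM, which is a limit of the assay and not a number; the step from compound 1 to compound 4 cannot be read. The compounds shown leave open how (4-methoxyphenyl)sulfanyl compares with 3,4-dichlorophenoxy at this position.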